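The compounds below may be only part of what the source reports. "The series", "measured", "known", "first", "only" and "open" are said of these compounds alone.

Measured compounds:
Compound 1, `Cc1oc(-c2c(Cl)cccc2Cl)nc1CN1CCC(C(=O)NCCCN2C[C@H](C)C[C@H](C)C2)CC1`: 0.0483 h
Compound 2, `Cc1cccc(F)c1-c1nc(CN2CCC(C(=O)NCCCN3C[C@H](C)C[C@H](C)C3)CC2)c(C)o1`: 0.0733 h

Both were tested in an ADME assay on microsomes from liver (Rattus norvegicus) for metabolic stability, read by LC-MS, using NADPH, at 37 degrees C; a lower number here means that the compound disappears faster, a higher number that the compound lasts longer. Compound 2 holds the higher of the two numbers, and its nearest neighbour is compound 1, separated by a 1.5-fold higher number from compound 1 to compound 2 (0.18 log units; within the scatter), a step that does not exceed the scatter of repeated measurements. The two values therefore cannot be told apart with confidence.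

Compound 3, `COc1ccc(-c2nc(CN3CCC(C(=O)NCCCN4C[C@H](C)C[C@H](C)C4)CC3)c(C)o2)cc1OC`, has not yet been measured in this assay. It differs from compound 2 in one place: 3,4-dimethoxyphenyl in place of 2-fluoro-6-methylphenyl on an aromatic carbon.

Among the compounds with values here, only one measured step is available, that from compound 1 to compound 2, and it concerns a different exchange on the same aromatic carbon; it was small and within the scatter. Within the data shown here, no measured pair shows what the 3,4-dimethoxyphenyl group does here, so there is no direct guide. On this basis, the account expects no step beyond the scatter in this assay from compound 2 to compound 3, expressed as a 1.2-fold lower number from compound 2 to compound 3 (0.09 log units; within the scatter). For compound 3 the expected half-life is 0.06 h, with a range from 0.025 h to 0.15 h.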

Compound 3, half-life: > 0.5 h
Compound 3: no number, only a limit; the forecaster's own chance of this, stated with the estimate: 5%; at least 8.3-fold (0.92 log units) between middle value and limit.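

In this assay, the aromatic carbon of the five-membered aromatic ring with 1 nitrogen and 1 oxygen proves able to carry a change beyond the scatter, which the earlier exchange between two phenyl groups did not show: 3,4-dimethoxyphenyl gives an at least 6.8-fold higher number from compound 2 to compound 3 (0.83 log units; beyond the scatter) and an at least 10-fold higher number from compound 1 to compound 3 (1.01 log units; beyond the scatter). The entering group brings 2 hydrogen-bond acceptors where 2-fluoro-6-methylphenyl has 0, and 10 heavy atoms against 8, but nothing measured here ties the step to either count. The reading for compound 3 is a limit of the assay and not a number, so both steps give only a lower bound on the size of the change: the limit of > 0.5 h in this assay, at which 1 of the 3 values shown sits.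

The compounds shown leave open whether both methoxy groups are needed, since a phenyl ring with a single methoxy group or with no substituent at all would separate their shares in the step. They also leave open how the position responds to other oxygen-bearing groups on the phenyl ring, such as ethoxy or hydroxy.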